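A few compounds are considered here, and "the series" means these few. Any claim that something is new, unique, unknown or untested is made for them only; others in the source may bear on it.

Compound 1, `Cn1nc2c(=O)n(CC3(O)CCN(Cc4ccc(-c5ccco5)cc4Cl)CC3)cnc2c1-c1ccc(CNC2CC2)cc1`: 54.1 nM
Compound 2, `Cn1nc2c(=O)n(CC3(O)CCN(Cc4ccc(-c5ccco5)cc4Cl)CC3)cnc2c1-c1ccc(C(=N)N)cc1`: 87.5 nM

In an assay on isolated protein for inhibition of ubiquitin carboxyl-terminal hydrolase 7 (Homo sapiens), with stated times of 30 min and 2 h (a higher number here means a weaker inhibitor, a lower number a stronger inhibitor), compound 2 gives the higher of the two numbers, yet it sits within the scatter of compound 1, so the two cannot be ranked. Compound 3, `Cn1nc2c(=O)n(CC3(O)CCN(Cc4ccc(-c5ccco5)cc4Cl)CC3)cnc2c1-c1ccc(Cl)cc1`, carries one chlorine atom in place of a group of 3 heavy atoms (1 carbon, 2 nitrogen; no ring), on an aromatic carbon. Within the data shown here, the one measured step that touches this aromatic carbon is a 1.6-fold higher number from compound 1 to compound 2 (0.21 log units; within the scatter), an exchange of two groups that left the number essentially unchanged. Among the measured compounds shown here, a single chlorine is a smaller and quite different group, and no measured compound shows what that does here. A modest rise in the number, a 2.3-fold higher number from compound 2 to compound 3 (0.36 log units; beyond the scatter), is expected, and compound 3 is estimated at 200 nM, within 60 nM to 700 nM.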

Compound 3, half-maximal inhibitory concentration: 143 nM
For compound 3 the middle estimate is 1.4-fold (0.15 log units) above the measured one, within the range that was stated.
By their numbers in this assay, from the lowest: compounds 1, 2 and 3 (each within the scatter of the next, the first and the last beyond it).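

In this assay, the swap to a single chloro on this aromatic carbon gives a 1.6-fold higher number from compound 2 to compound 3 (0.21 log units; within the scatter), so that exchange cannot be told apart from no change. Among these compounds, measured against the (cyclopropylamino)methyl group, the same chloro gives a 2.6-fold higher number from compound 1 to compound 3 (0.42 log units; beyond the scatter), the first step at this position to clear the scatter, and it is still modest. A lone chlorine, with no hydrogen-bond donors or acceptors, therefore keeps the number within a modest step of the larger groups. Nothing available explains these steps. The compounds shown leave open what a carboxylic acid, a primary amine or a longer chain would give on this carbon.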